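Cytotoxicity of a dechlorinated analogue in Vero cells

A few compounds are considered here, and "the series" means these few. Any claim that something is new, unique, unknown or untested is made for them only; others in the source may bear on it.

Of the compounds shown here, three sharing one core have been tested in an ADME assay on Vero cells (Chlorocebus sabaeus) for cytotoxicity, read by MTT assay, with a stated time of 72 h; on this read-out higher numbers stand for weaker inhibition and lower numbers for stronger inhibition. Compound 1 `CCn1cc(C(=O)N2N=C(c3cc4ccccc4o3)CC2c2ccccc2OC)c(=O)c2ccc(C)nc21` carries a 2-methoxyphenyl on a saturated ring carbon; in this assay compound 1 gives only a limit, > 187000 nM. Compound 2 `CCn1cc(C(=O)N2N=C(c3cc4ccccc4o3)CC2c2ccc(N(C)C)cc2)c(=O)c2ccc(C)nc21` carries a 4-(dimethylamino)phenyl in its place, and in this assay compound 2 likewise gives a limit, > 206000 nM. Compound 3 `CCn1cc(C(=O)N2N=C(c3cc4ccccc4o3)CC2c2ccc(Cl)cc2)c(=O)c2ccc(C)nc21` carries a 4-chlorophenyl, and in this assay compound 3 reaches only a limit, > 160000 nM. Compound 3 thus cannot be placed among the three: every value shown is a limit (the limit of > 160000 nM in this assay, at which 1 of the 3 values shown sits, (the limit of > 187000 nM in this assay, at which 1 of the 3 values shown sits), (the limit of > 206000 nM in this assay, at which 1 of the 3 values shown sits)), and the steps a step that the two limits leave unreadable from compound 1 to compound 2, a step that the two limits leave unreadable from compound 1 to compound 3 and a step that the two limits leave unreadable from compound 2 to compound 3 cannot be sized.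

Compound 4 `CCn1cc(C(=O)N2N=C(c3cc4ccccc4o3)CC2c2ccccc2)c(=O)c2ccc(C)nc21` differs from compound 3 by hydrogen in place of chloro on an aromatic carbon. For the measured compounds named here, no measured step bears directly on this change, and the three measured steps, each running between limits, give no size in either direction. Compound 4 is therefore expected to remain at the limit as well, with the step that the limit leaves unreadable from compound 3 to compound 4 expected to be no larger than the scatter. The value of compound 4 in this assay is estimated at 200000 nM, within a range from 100000 nM to 400000 nM.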

Compound 4, half-maximal inhibitory concentration: > 210000 nM
Compound 4 ended at the assay's limit; the forecaster's own chance of this, stated with the estimate: 90%; at least 1.0-fold (0.02 log units) between middle value and limit.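

In this assay compound 4 also gives only a limit, > 210000 nM. For the compounds shown here, compound 1, compound 2 and compound 3 rest on limits too, so no step to compound 4 can be read. The compounds shown leave open at what concentration any of them would reach half-maximal inhibition, and whether the substituent on the phenyl ring changes that concentration.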